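Swapping Bromo for Nitro in Aryl Triazenes

The source may hold more compounds than are shown below. What is called first, only, known or untested is meant among the compounds shown, and "the series" means these compounds.

This small set concerns four aryl triazenes tested in an ADME assay on Vero cells (Chlorocebus sabaeus) for cytotoxicity, read by crystal violet staining; on this read-out lower numbers stand for higher toxicity in this test and higher numbers for lower toxicity in this test. Compound 1 has the structure `O=[N+]([O-])c1ccc(/N=N/N2CCCC2)cc1`, compound 2 the structure `Brc1cccc(/N=N/N2CCCCC2)c1`, compound 3 the structure `Brc1ccc(/N=N/N2CCCC2)cc1`, and compound 4, not yet tested, the structure `O=[N+]([O-])c1cccc(/N=N/N2CCCCC2)c1`.

In this assay compound 1 gives 90000 nM, and compound 2 gives 85000 nM; these two numbers lie within the scatter of each other. For compound 3 the result is a limit of the assay rather than a number, >= 100000 nM.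

Within the data shown here, the one change that can be counted between measured compounds is nitro in place of bromo on an aromatic carbon. It brought an at least 1.1-fold lower number from compound 3 to compound 1 (0.04 log units; that floor lies within the scatter); that step is known only as a floor because of the limit of >= 100000 nM in this assay, at which 1 of the 3 values shown sits. The same kind of change leads from compound 2 to compound 4, namely (nitro in place of bromo on an aromatic carbon); around the place the two differ, since in one case the nitro sits para to a group of 7 heavy atoms and in the other meta to a group of 8 heavy atoms. The difference between the two cores of compound 2 and compound 3 is not broken down here.

The step expected here, a 1.1-fold lower number from compound 2 to compound 4 (0.03 log units; within the scatter), rests on compound 2 at 85000 nM and on the measured step of an at least 1.1-fold lower number from compound 3 to compound 1 (0.04 log units; that floor lies within the scatter), which stayed within the scatter. For compound 4 the estimated value is 80000 nM, expected between 40000 nM and 100000 nM.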

Compound 4, half-maximal cytotoxic concentration: 83000 nM
Beside the measured number, compound 4's estimate is 1.0-fold (0.02 log units) below it; the measured number falls inside the stated range.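

In this assay, nitro in place of bromo on the core of compound 2 brought a 1.0-fold lower number from compound 2 to compound 4 (0.01 log units; within the scatter), so on this core the two numbers cannot be told apart and the swap shows no effect that can be read. This fits with the earlier pair, yet it does not show that the swap carries over unchanged from one core to the other: the same change on two cores in this assay, an at least 1.1-fold lower number (0.04 log units; that floor lies within the scatter) from compound 3 to compound 1 and a 1.0-fold lower number (0.01 log units; within the scatter) from compound 2 to compound 4; the limit leaves it open whether they differ The earlier step is only a floor and the real step could be larger, because compound 3 sits at a limit of the assay and not at a number: the limit of >= 100000 nM in this assay, at which 1 of the 4 values shown sits.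

The two pairs differ from each other in more than one place, so the compounds shown leave open whether the place of the group on the aromatic ring or the rest of the core matters on its own. They also leave open how a different group on the same aromatic carbon, such as an amine or a carboxylic acid, would read in this assay.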